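A few compounds are considered here, and "the series" means these few. Any claim that something is new, unique, unknown or untested is made for them only; others in the source may bear on it.

Measured so far in a functional assay for antagonist activity at Adrenergic receptor alpha-1 (Rattus norvegicus); a higher number here means weaker binding, a lower number tighter binding:
compound 1, `Cc1ccc(N2CCN(CCNC(=O)c3cc4ccccc4o3)CC2)c(C)c1`, gives 43.7 nM
compound 2, `Cc1ccc(N2CCN(CCNC(=O)c3ccncc3)CC2)c(C)c1`, gives 85.1 nM
compound 3, `Cc1ccc(N2CCN(CCNC(=O)c3ccncc3)CC2)cc1`, gives 316 nM

Compound 4, `Cc1ccc(N2CCN(CCNC(=O)c3cc4ccccc4o3)CC2)cc1`, is not yet measured in this assay.

Between compound 2 and compound 3 the cores differ in one place: hydrogen in place of methyl on an aromatic carbon. That step reads a 3.7-fold higher number from compound 2 to compound 3 (0.57 log units; beyond the scatter).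

The change from compound 3 to compound 4 is 1-benzofuran-2-yl in place of pyridin-4-yl on a carbonyl carbon. The same change, at the same place word for word, is made from compound 2 to compound 1: 1-benzofuran-2-yl in place of pyridin-4-yl on a carbonyl carbon. It occurs twice among these compounds, and the measured instance gave a 1.9-fold lower number from compound 2 to compound 1 (0.29 log units; within the scatter).

For compound 4 in this assay, a step of the same kind is expected, a 1.9-fold lower number from compound 3 to compound 4 (0.27 log units; within the scatter), resting on compound 2 to compound 1 having given a 1.9-fold lower number from compound 2 to compound 1 (0.29 log units; within the scatter) and on compound 3 standing at 316 nM. Compound 4 is therefore estimated at 170 nM, expected between 75 nM and 380 nM.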

Compound 4, dissociation constant: 120 nM
Compound 4: the middle estimate sits 1.4-fold (0.15 log units) above what was measured, and the stated range covers the measured number.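

In this assay, 1-benzofuran-2-yl in place of pyridin-4-yl on the carbonyl carbon gives a 2.6-fold lower number from compound 3 to compound 4 (0.42 log units; beyond the scatter), and the step carries over between the two cores: the same change on two cores in this assay, a 1.9-fold lower number (0.29 log units; within the scatter) from compound 2 to compound 1 and a 2.6-fold lower number (0.42 log units; beyond the scatter) from compound 3 to compound 4, 1.4-fold (0.13 log units) apart, within the scatter of two such steps

Hydrogen in place of methyl on an aromatic carbon gives a 2.7-fold higher number from compound 1 to compound 4 (0.44 log units; beyond the scatter), and this step also holds on both amide groups: the same change on two cores in this assay, a 3.7-fold higher number (0.57 log units; beyond the scatter) from compound 2 to compound 3 and a 2.7-fold higher number (0.44 log units; beyond the scatter) from compound 1 to compound 4, 1.4-fold (0.13 log units) apart, within the scatter of two such steps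

The four compounds thus show the two changes behaving alike in each setting, but this is one square of compounds and does not show that either step would transfer to any other core.

Still open, from the compounds shown here alone, is whether a phenyl or thiophene group on the carbonyl carbon would follow the same step. Also open, going by these compounds, is whether a longer chain to the amide nitrogen would preserve it.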